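The compounds below may be only part of what the source reports. "The series", "measured", "known", "first", "only" and "open" are said of these compounds alone.

Compound 3 `COc1ccc(-c2cnc(NC(=O)c3ccc(F)cc3)n2C)cc1` is examined in a toxicity assay on THP-1 cells (Homo sapiens) for inhibition (on this read-out lower numbers stand for higher toxicity in this test and higher numbers for lower toxicity in this test), where compound 3 gives only a limit, >= 50000 nM. Compound 1 `COc1ccc(-c2cnc(NC(=O)C3CCCCC3)n2C)cc1` likewise returns a limit in this assay, > 100000 nM. Compound 2 `COc1ccc(-c2cnc(NC(=O)c3ccco3)n2C)cc1` also stands at a limit in this assay, > 100000 nM. All three values therefore rest at the limit of > 100000 nM in this assay, at which 2 of the 3 values shown sit, or (the limit of >= 50000 nM in this assay, at which 1 of the 3 values shown sits), and compound 3 stands among them without a readable number. The measured steps are a step that the two limits leave unreadable from compound 1 to compound 2, a step that the two limits leave unreadable from compound 1 to compound 3 and a step that the two limits leave unreadable from compound 2 to compound 3, none of which can be sized. Compound 4 `COc1ccc(-c2cnc(NC(=O)c3cnc[nH]3)n2C)cc1` differs from compound 3 by 1H-imidazol-5-yl in place of 4-fluorophenyl on a carbonyl carbon. For the measured compounds named here, no measured step bears on this change, so no step beyond the scatter is expected, and a limit is again likely. Compound 4 is therefore expected to give 100000 nM, within a range from 40000 nM to 250000 nM. For compound 4 the expected step is a step that the limit leaves unreadable from compound 3 to compound 4.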

Compound 4, half-maximal cytotoxic concentration: > 100000 nM
Compound 4 was reported as a limit; the forecaster's own chance of this, stated with the estimate: 85%; the middle value lies on the limit itself.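

Compound 4 gives only a limit in this assay, so its steps from compound 1, compound 2 and compound 3 cannot be read. The compounds shown leave open whether any group on the carbonyl carbon changes this read-out at all.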